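A few compounds are considered here, and "the series" means these few. Any claim that something is new, unique, unknown or untested is made for them only; others in the source may bear on it.

Working notes on the series in an assay for inhibition of Nitric oxide synthase, inducible (Homo sapiens), read by scintillation counting, with a stated time of 30 min, tested at 1 mM; on this read-out lower numbers stand for less inhibition and higher numbers for more inhibition at the one concentration tested (going by the name of the read-out). Among the compounds with values here, compound 1 `COc1ccc(N)c(C(=O)CCNC(=O)C2CC2)c1` gives 2.66% and compound 2 `COc1ccc(N)c(C(=O)CCNC(=O)C2CCCC2)c1` gives 0.61%; the one measured step, a number 2.1 percentage points lower from compound 1 to compound 2 (within the scatter), is within the scatter. Compound 3 `CCNC(=S)NCCC(O)c1ccccc1N` gives 19.4%, the highest of the three numbers, beyond the scatter from both compound 1 and compound 2. Compound 4 `CCNC(=O)NCCC(O)c1ccccc1N` is not yet measured; it differs from compound 3 by a group of 5 heavy atoms (3 carbon, 1 nitrogen, 1 oxygen; no ring) in place of a group of 5 heavy atoms (3 carbon, 1 nitrogen, 1 sulfur; no ring), on an amine nitrogen. Within the data shown here, no measured step concerns this kind of exchange: the only step on record, from a cyclopropyl to a cyclopentyl on a carbonyl carbon, does not bear on it. The expected step is therefore uncertain, a number 9.4 percentage points lower from compound 3 to compound 4 (within the scatter), set as a modest drop with wide bounds. Compound 4 is estimated at 10%, between 0% and 25%.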

Compound 4, a percentage reported as inhibition, at one concentration (the size of the read-out at that concentration, not a potency): 18.3%
Compound 4: the middle estimate sits 8.3 percentage points below what was measured; measured number inside the range.
By their numbers in this assay, from the lowest: compounds 2 and 1 (each within the scatter of the next); then compounds 4 and 3 (each within the scatter of the next).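

At this amine nitrogen in this assay, ethylcarbamoyl in place of the sulfur-bearing group of equal heavy-atom count gives a number 1.1 percentage points lower from compound 3 to compound 4 (within the scatter). Oxygen and sulfur in this group are therefore not told apart by this read-out, which is the first information on this position, since the earlier step concerned only a group on a carbonyl carbon. No evidence on hand bears on this result. Still open, as far as these compounds go, is whether a longer chain in place of the ethyl would leave the number unchanged. A guanidine on the same nitrogen is also untested in the compounds shown.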